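Methoxy-for-hydrogen step in a cytotoxicity series

The source may report more compounds than this note shows. Statements on the series, on what has been measured and on what is new or still open speak of the compounds shown alone.

Three compounds have numbers in a functional assay on RXF 393 cells (Homo sapiens) for cytotoxicity, read by sulforhodamine B assay, with a stated time of 48 h, tested at 10 uM; on this read-out higher numbers stand for a weaker effect at the one concentration tested and lower numbers for a stronger effect. Compound 1 `COc1cc(-c2cc(/C=C/C(=O)c3ccc(N)cc3)[nH]n2)cc(OC)c1OC` gives -64%. Compound 2 `COc1ccc(-c2cc(/C=C/C(=O)c3ccc(OC)c(OC)c3)[nH]n2)cc1` gives -82%. Compound 3 `COc1ccc(-c2cc(/C=C/C(=O)c3cc(OC)c(OC)c(OC)c3)[nH]n2)cc1OC` gives -80%, the second highest of the three; its nearest neighbour is compound 2, within the scatter, while compound 1 stands beyond the scatter above it. Compound 4 `COc1cc(C(=O)/C=C/c2cc(-c3cc(OC)c(OC)c(OC)c3)n[nH]2)cc(OC)c1OC` is not yet measured. It differs from compound 3 in one place: methoxy in place of hydrogen on an aromatic carbon. No step between measured compounds isolates such a change, so its size is unknown from the numbers shown; compounds 2 and 3, both carrying several methoxy groups, sit within the scatter of each other, which argues for no step beyond the scatter. From compound 3 the expected step is a number 2 percentage points higher from compound 3 to compound 4 (within the scatter). Compound 4 is thus estimated at -78%, within -95% to -58%.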

Compound 4, a percentage reported as activity, at one concentration (the size of the read-out at that concentration, not a potency): -88%
The estimate for compound 4 lay 10 percentage points above the measured number, and the stated range covers the measured number.
By their numbers in this assay, from the lowest: compounds 4, 2 and 3 (each within the scatter of the next); then compound 1.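

Working notes: in this assay, the methoxy-for-hydrogen change gives the first isolated step in the series, a number 8 percentage points lower from compound 3 to compound 4 (within the scatter), and this stays within the scatter. A methoxy group is therefore tolerated on this aromatic carbon, ortho to a methoxy group and meta to a large group, with no shift beyond the scatter. No accompanying measurement bears on this result.

From the compounds shown here alone, whether a hydroxy group, a fluorine atom or a longer alkoxy chain at this position would hold the read-out remains open. Going by these compounds, whether the same change gives a similar step on other compounds also remains open.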